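A few compounds are considered here, and "the series" means these few. Any claim that something is new, unique, unknown or untested is made for them only; others in the source may bear on it.

Among the compounds with values here, measured in a functional assay on Raji cells (Homo sapiens) for cytotoxicity, with a stated time of 72 h (a higher number here means that more compound is needed for the effect, a lower number that less compound is needed), every value so far is a limit of the assay rather than a number.
Compound 1 `C=C[C@@](C)(/C=C/c1ccc(OCc2ccccc2)cc1)CCC=C(C)C` gives > 26000 nM.
Compound 2 `C=C[C@@](C)(/C=C/c1ccc(O)cc1)CC/C=C(C)/C=C/C(=O)OCC` gives > 26000 nM.
Compound 3 `CCOc1ccc(/C=C/[C@@](C)(/C=C/c2ccc(O)cc2)CCC=C(C)C)cc1` gives > 26000 nM.

Compound 1 therefore stands at the limit shared by all three, (the limit of > 26000 nM in this assay, at which 3 of the 3 values shown sit), and nothing on these numbers separates it from compound 2 or compound 3. Compound 4 `C=C[C@@](C)(/C=C/c1ccc(-c2ccc(Cl)cc2)cc1)CCC=C(C)C` carries 4-chlorophenyl in place of benzyloxy on an aromatic carbon. Within the data shown here, no step between measured compounds is known, so the size of this change cannot be read from the series, and the only guide is that every measured compound sits at the limit. For compound 4 the expected outcome is again a limit, the step being expected as a step that the limit leaves unreadable from compound 1 to compound 4. Compound 4 is estimated at 30000 nM, in the range 8000 nM to 100000 nM.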

Compound 4, half-maximal effective concentration: > 26000 nM
Compound 4 was reported as a limit; the forecaster's own chance of this, stated with the estimate: 75%; the middle value is on the limit's open side.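

Compound 1 and compound 4 are both limits, so no step can be read for 4-chlorophenyl in place of benzyloxy: the limit of > 26000 nM in this assay, at which 4 of the 4 values shown sit.

The compounds shown leave open whether any change to the shared core gives a measurable value in this assay.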